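The source may report more compounds than this note shows. Statements on the series, on what has been measured and on what is new or still open speak of the compounds shown alone.

Series on the shared core of compound 1 `CSc1ccc(CNc2nc(SC)nc3ncccc23)cc1`, which in a functional assay on CCRF-CEM cells (Homo sapiens) for cytotoxicity, read by MTT assay, with a stated time of 72 h (a higher number here means a weaker inhibitor of growth, a lower number a stronger inhibitor of growth), gives 5350 nM. Compound 2 `COc1ccc(CNc2nc(SC)nc3ncccc23)cc1` in this assay gives > 100000 nM, which is a limit of the assay and not a number (the limit of > 100000 nM in this assay, at which 1 of the 2 values shown sits). For compound 2 in this assay, therefore, only a limit is known. For the measured compounds named here, the one measured step, an at least 18-fold higher number from compound 1 to compound 2 (1.27 log units; beyond the scatter), does not test the change hydrogen in place of methoxy on an aromatic carbon that leads to compound 3 `CSc1nc(NCc2ccccc2)c2cccnc2n1`. Without a measured precedent, compound 3 in this assay is expected near 30000 nM, within 5000 nM to 100000 nM. The estimated step of an at least 3.3-fold lower number from compound 2 to compound 3 (0.52 log units; beyond the scatter) is loosely bounded because compound 2 sits at the limit (the limit of > 100000 nM in this assay, at which 1 of the 2 values shown sits).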

Compound 3, concentration for 50% growth inhibition: 56300 nM
For compound 3 the middle estimate is 1.9-fold (0.27 log units) below the measured one, and the stated range covers the measured number.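

In this assay, methylsulfanyl at this place, para to a large group, now has a measured comparison with hydrogen on both sides: an 11-fold higher number from compound 1 to compound 3 (1.02 log units; beyond the scatter). Methoxy and hydrogen are not separated by the other step, an at least 1.7-fold lower number from compound 2 to compound 3 (0.24 log units; that floor lies within the scatter). Compound 2 gives only a limit of the assay: the limit of > 100000 nM in this assay, at which 1 of the 3 values shown sits.

On these data alone, the true size of the gap between methoxy and hydrogen stays open, as does whether methylsulfanyl's advantage extends to a longer chain such as ethylsulfanyl. As far as these compounds go, how an amine or a chlorine atom at this place would compare also remains open.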